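The compounds below may be only part of what the source reports. "The series", "measured", "known", "first", "only" and "open" are said of these compounds alone.

In a toxicity assay on HepG2 2.2.15 cells (Homo sapiens) for cytotoxicity, read by CellTiter-Glo (on this read-out higher numbers stand for lower toxicity in this test and lower numbers for higher toxicity in this test), compound 1 (`O=C1CC(c2ccc(F)cc2)CN1c1cnn2c1CN(C(=O)Nc1cc(F)c(F)c(F)c1)C(C1CC1)C2`) gives 32100 nM and compound 2 (`O=C(Nc1cc(F)c(F)c(F)c1)N1Cc2c(-c3ccc(F)cc3)cnn2CC1C1CC1`) gives 38500 nM so that compound 2 stands level with compound 1 within the usual scatter. Compound 3 (`O=C1CC(c2ccccn2)CN1c1cnn2c1CN(C(=O)Nc1cc(F)c(F)c(F)c1)C(C1CC1)C2`) carries 2-oxo-4-(pyridin-2-yl)pyrrolidin-1-yl in place of 4-fluorophenyl on an aromatic carbon. Among the compounds with values here, no measured pair shows this change on its own, so no step beyond the scatter is expected in this assay and the range is kept wide. The expected change is a 1.0-fold lower number from compound 2 to compound 3 (0.01 log units; within the scatter) as estimated here. Compound 3 is estimated at 38000 nM and expected to fall between 18000 nM and 80000 nM.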

Compound 3, half-maximal cytotoxic concentration: 96200 nM
The estimate for compound 3 lay 2.5-fold (0.40 log units) below the measured number; measured number outside the range, above it.
By their numbers in this assay, from the lowest: compounds 1 and 2 (each within the scatter of the next); then compound 3.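

In this assay, the change on the aromatic carbon now gives a step beyond the scatter, a 2.5-fold higher number from compound 2 to compound 3 (0.40 log units; beyond the scatter), and the higher number stands for lower toxicity in this test. Compound 1 and compound 2, which both carry 4-fluorophenyl, stood level, yet pyridin-2-yl in place of 4-fluorophenyl on a saturated ring carbon gives a 3.0-fold higher number from compound 1 to compound 3 (0.48 log units; beyond the scatter). Nothing available here accounts for this step. As far as these compounds go, whether plain phenyl on that saturated ring carbon would give a similar step stays open, as does the outcome with pyridin-3-yl there.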